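The source may report more compounds than this note shows. Statements on the series, on what has been measured and on what is new or still open speak of the compounds shown alone.

Measured so far in a functional assay on MCF7 cells (Homo sapiens) for antiproliferative activity, read by MTT assay, with a stated time of 48 h (a higher number here means a weaker inhibitor, a lower number a stronger inhibitor), are two compounds:
- compound 1 `O=[N+]([O-])c1cccc(-c2nn(-c3ccccc3)cc2C(Nc2nc3ccccc3s2)c2c(O)ccc3ccccc23)c1` gives 43900 nM here
- compound 2 `Cc1ccc2nc(NC(c3cn(-c4ccccc4)nc3-c3cccc([N+](=O)[O-])c3)c3c(O)ccc4ccccc34)sc2c1` gives 38400 nM here

Among the compounds with values here, compound 2 stands level with compound 1, the only other measured compound, as the two numbers lie within the scatter of each other. Compound 3 `Cc1ccc2nc(NC(c3cn(-c4ccccc4)nc3-c3cccc(Cl)c3)c3c(O)ccc4ccccc34)sc2c1` keeps the core of compound 2 and exchanges one group, (chloro in place of nitro on an aromatic carbon), which is chloro in place of nitro on an aromatic carbon. Within the data shown here, the single measured step, a 1.1-fold lower number from compound 1 to compound 2 (0.06 log units; within the scatter), is a different change, methyl in place of hydrogen on an aromatic carbon, and no measured pair tests the new exchange. With so little to go on, no step beyond the scatter is expected in this assay, and no direction can be firmly argued. The expected change is a 1.2-fold lower number from compound 2 to compound 3 (0.08 log units; within the scatter) as estimated here. Compound 3 is estimated at 32000 nM, with an expected range from 13000 nM to 70000 nM in this estimate.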

Compound 3, half-maximal inhibitory concentration: 49700 nM
Compound 3: middle estimate off by 1.6-fold (0.19 log units), on the low side; the measured number falls inside the stated range.
By their numbers in this assay, from the lowest: compounds 2, 1 and 3 (each within the scatter of the next).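

In this assay, the exchange of 3-nitrophenyl for 3-chlorophenyl gives a 1.3-fold higher number from compound 2 to compound 3 (0.11 log units; within the scatter). Within the data shown here, until now every compound carried the nitro group, and this step is the first reading at this position on the six-membered aromatic ring of carbon only: a single chlorine atom stands in for the three heavy atoms of nitro, and the two hydrogen-bond acceptors go with it, without a step beyond the scatter. Nothing measured here accounts for the two groups reading alike.

On these data alone, whether an amine or a carboxylic acid at this position would move the number beyond the scatter remains open. Also open, as far as these compounds go, is whether the same exchange would read alike on compound 1, which lacks the methyl group of compound 2.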